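Hydrazide and hydrazone analogues: cytotoxicity on liver cells

The source may hold more compounds than are shown below. What is called first, only, known or untested is meant among the compounds shown, and "the series" means these compounds.

Measured compounds:
Compound 1, `CC(C)(C)c1ccc(C(=O)N/N=C/c2cc(I)c(O)c(I)c2)cc1`, 45900 nM
Compound 2, `O=C(N/N=C/c1cc(I)c(O)c(I)c1)c1ccc(F)cc1`, 117000 nM
Compound 3, `CC(C)(C)c1ccc(C(=O)NNC(=O)c2cc(I)cc(I)c2O)cc1`, 87300 nM

Three compounds were tested in a functional assay on HepG2 cells (Homo sapiens) for cytotoxicity, with a stated time of 24 h; on this read-out higher numbers stand for weaker inhibition and lower numbers for stronger inhibition. Compound 1 gives 45900 nM, and compound 2, which differs from it by fluoro in place of tert-butyl on an aromatic carbon, gives 117000 nM; that change made a 2.5-fold higher number from compound 1 to compound 2 (0.41 log units; beyond the scatter). Compound 3, built on a different core, gives 87300 nM; the difference between the core of compound 1 and the core of compound 3 is not broken down here, and its value stands within the scatter of both compound 1 and compound 2.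

Compound 4, `O=C(NNC(=O)c1cc(I)cc(I)c1O)c1ccc(F)cc1`, is not yet measured. It differs from compound 3 by fluoro in place of tert-butyl on an aromatic carbon, the same change that was made from compound 1 to compound 2, at the same place. Resting on that one step, a 2.5-fold higher number from compound 1 to compound 2 (0.41 log units; beyond the scatter), compound 4 is expected to give a step of a 2.3-fold higher number from compound 3 to compound 4 (0.36 log units; beyond the scatter) in this assay, as a single precedent gives only a rough guide. Compound 4 is therefore estimated at 200000 nM, between 90000 nM and 450000 nM.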

Compound 4, half-maximal inhibitory concentration: 87000 nM
Compound 4: middle estimate off by 2.3-fold (0.36 log units), on the high side, and the stated range ends above it.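

In this assay fluoro in place of tert-butyl gives a 1.0-fold lower number from compound 3 to compound 4 (0.00 log units; within the scatter) and so no readable difference on this core, whereas the same change on the core of compound 1 gave a step beyond the scatter. The size of the earlier step was thus not repeated on the second core, but this does not show that the change truly acts differently on the two cores, and two pairs of compounds give no rule for the series. Set side by side, the two steps cannot be told apart: the same change on two cores in this assay, a 2.5-fold higher number (0.41 log units; beyond the scatter) from compound 1 to compound 2 and a 1.0-fold lower number (0.00 log units; within the scatter) from compound 3 to compound 4, 2.6-fold (0.41 log units) apart, within the scatter of two such steps.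

The compounds shown leave open whether other groups at this place on the aromatic ring, such as chloro, methoxy or an amine, would follow the step seen on the core of compound 1 or the one seen on the core of compound 3. They also leave open how the same change would read on any further core, or in any other assay.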